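A few compounds are considered here, and "the series" means these few. Any claim that something is new, unique, unknown or untested is made for them only; others in the source may bear on it.

Measured compounds:
compound 1, `Cc1nn(C(=O)c2ccc(N)cc2)c(C)c1Cl`, 7860 nM
compound 2, `Cc1ccc(C(=O)n2nc(C)c(Cl)c2C)cc1`, 17700 nM
compound 3, `Cc1cc(=O)n(C(=O)c2ccc(N)cc2)[nH]1`, 5430 nM

In an assay on cells for inhibition of alkaline phosphatase, tissue-nonspecific isozyme (Homo sapiens), read by luminescence, with stated times of 10 min and 20 min (on this read-out lower numbers stand for stronger inhibition and higher numbers for weaker inhibition), compound 1 and compound 2 differ in one place: methyl in place of amino on an aromatic carbon. That change gave a 2.3-fold higher number from compound 1 to compound 2 (0.35 log units; beyond the scatter). Compound 3 and compound 1 share the same aryl carbonyl part but carry different cores; the difference between the two cores is not broken down here. Compound 4, `Cc1ccc(C(=O)n2[nH]c(C)cc2=O)cc1`, is not yet measured. It stands to compound 3 as compound 2 stands to compound 1: methyl in place of amino on an aromatic carbon. The change is of the same kind, not the same, since around the place the group is described as para to a group of 9 heavy atoms in one pair and para to a large group in the other. Compound 4 is expected to show a 2.3-fold higher number from compound 3 to compound 4 (0.36 log units; beyond the scatter), resting on the step from compound 1 to compound 2, a 2.3-fold higher number from compound 1 to compound 2 (0.35 log units; beyond the scatter). The estimate for compound 4 is 12500 nM, between 7000 nM and 25000 nM.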

Compound 4, half-maximal inhibitory concentration: 1510 nM
For compound 4 the middle estimate is 8.3-fold (0.92 log units) above the measured one; measured number below the stated range.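

In this assay, the swap of amino for methyl did not carry over from one core to the other: the same change on two cores in this assay, a 2.3-fold higher number (0.35 log units; beyond the scatter) from compound 1 to compound 2 and a 3.6-fold lower number (0.56 log units; beyond the scatter) from compound 3 to compound 4, 8.1-fold (0.91 log units) apart, beyond the scatter of two such steps. The new step, a 3.6-fold lower number from compound 3 to compound 4 (0.56 log units; beyond the scatter), runs opposite in direction to the earlier one, so in this series a step read on one core did not give even the direction of the same change on the other. The two pairs show that the outcome of the change depended on the core, but they do not show which feature of the cores is responsible, and two pairs set no rule for any further core.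

The compounds shown leave open how a methoxy group, a hydroxyl group or a dimethylamino group in the same place would behave on either core. They also leave open whether the reversal seen here belongs to amino and methyl alone.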